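Triazole in Place of the Hydroxypentyl Chain

The source may report more compounds than this note shows. Statements on the series, on what has been measured and on what is new or still open speak of the compounds shown alone.

Compound 3 `CC(C)Cn1c(=O)n(C)c(=O)c2nc(CCCCCO)c(Cc3cccc4ccccc34)nc21` gives the lowest of the two numbers shown in a functional assay on Raji cells (Homo sapiens) for inhibition, read by MTT assay, with a stated time of 96 h (a higher number here means that more compound is needed for the effect, a lower number that less compound is needed), namely 58 nM. Compound 2 `CC(C)Cn1c(=O)n(C)c(=O)c2nc(CCCCO)c(Cc3cccc4ccccc34)nc21` gives 285 nM in this assay, and a 4.9-fold lower number from compound 2 to compound 3 (0.69 log units; beyond the scatter). For compound 1 `CC(C)Cn1c(=O)n(C)c(=O)c2nc(C(=O)N(C)CCCO)c(Cc3cccc4ccccc34)nc21` this assay reports only a limit, > 10000 nM. Compound 4 `CC(C)Cn1c(=O)n(C)c(=O)c2nc(-c3c(CCCO)nnn3C)c(Cc3cccc4ccccc34)nc21` differs from compound 3 by 4-(3-hydroxypropyl)-1-methyl-1H-1,2,3-triazol-5-yl in place of 5-hydroxypentyl on an aromatic carbon. The steps of an at least 35-fold lower number from compound 1 to compound 2 (1.54 log units; beyond the scatter) and an at least 170-fold lower number from compound 1 to compound 3 (2.23 log units; beyond the scatter) show that exchanging the carbamoyl group for a hydroxyalkyl chain lowered the number greatly; compound 4 keeps the hydroxyalkyl part but adds an aromatic ring with more acceptors, so a moderate rise is expected rather than a return to the limit. Compound 4 is estimated at 400 nM, between 60 nM and 3000 nM, which means a 6.9-fold higher number from compound 3 to compound 4 (0.84 log units; beyond the scatter).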

Compound 4, half-maximal effective concentration: > 10000 nM
Compound 4 was reported as a limit; the forecaster's own chance of this, stated with the estimate: 20%; middle value at least 25-fold (1.39 log units) from the limit.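

In this assay, placing 4-(3-hydroxypropyl)-1-methyl-1H-1,2,3-triazol-5-yl on this aromatic carbon gives an at least 170-fold higher number from compound 3 to compound 4 (2.23 log units; beyond the scatter) and an at least 35-fold higher number from compound 2 to compound 4 (1.54 log units; beyond the scatter), so a terminal hydroxy group carried on a chain does not by itself keep the number low. The value of compound 4 is a limit, and the step from compound 1 to compound 4 cannot be read: the limit of > 10000 nM in this assay, at which 2 of the 4 values shown sit.

The compounds shown leave open whether the triazole ring itself or the hydroxypropyl chain on it accounts for the rise. They also leave open whether a longer chain on that ring, or an amine in place of its terminal hydroxy group, would bring the number back down.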